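A few compounds are considered here, and "the series" means these few. Any claim that something is new, unique, unknown or untested is made for them only; others in the source may bear on it.

Measured so far:
compound 1 `Cc1nc2cc(Br)ccc2nc1Oc1ccc(N)cc1` — 0.00081 ug/mL
compound 2 `Cc1nc2cc(Br)ccc2nc1Oc1ccc(/N=C\c2ccc(Cl)cc2)cc1` — 0.00008 ug/mL
compound 3 `Cc1nc2cc(Br)ccc2nc1Oc1ccc(C=O)cc1` — 0.0328 ug/mL

Among these three, compound 3 gives the highest number in a functional assay on MCF7 cells (Homo sapiens) for inhibition, read by sulforhodamine B assay, with a stated time of 72 h (a higher number here means a weaker inhibitor, a lower number a stronger inhibitor), so it is the weakest inhibitor of the set. The step to compound 4 `Cc1nc2cc(Br)ccc2nc1Oc1ccc(/C=N\c2ccc(Cl)cc2)cc1` replaces (a group of 9 heavy atoms (7 carbon, 1 nitrogen, 1 chlorine; one six-membered aromatic ring of carbon only) in place of a group of 2 heavy atoms (1 carbon, 1 oxygen; no ring), on an aromatic carbon). The closest guide is the reverse of this change, a 410-fold higher number from compound 2 to compound 3 (2.61 log units; beyond the scatter), where the same nine-atom group was lost and the number rose sharply; a 10-fold lower number from compound 1 to compound 2 (1.01 log units; beyond the scatter) also shows that adding a chlorophenyl imine lowered the number. Compound 4 is only an isomer of compound 2, so a large drop is expected in this assay, roughly an 82-fold lower number from compound 3 to compound 4 (1.91 log units; beyond the scatter). Compound 4 is therefore estimated at 0.0004 ug/mL, with a likely range from 0.00004 ug/mL to 0.004 ug/mL.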

Compound 4, half-maximal inhibitory concentration: 0.0126 ug/mL
Compound 4: middle estimate off by 32-fold (1.50 log units), on the low side, and the stated range ends below it.
By their numbers in this assay, from the lowest: compound 2; then compound 1; then compound 4; then compound 3.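

Reversing the direction of the imine link matters greatly in this assay (a 160-fold higher number from compound 2 to compound 4 (2.20 log units; beyond the scatter)), even though the two compounds are isomers. In this reversed form, the chlorophenyl group adds only a modest gain over formyl (a 2.6-fold lower number from compound 3 to compound 4 (0.42 log units; beyond the scatter)), and the result remains weaker than the plain amino compound (a 16-fold higher number from compound 1 to compound 4 (1.19 log units; beyond the scatter)). No evidence here explains why direction matters so much. As far as these compounds go, it remains open how an amide or a saturated amine link would compare, and whether fluorine in place of chlorine would change the picture in either imine direction.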